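Capping the Hydroxy Group of Compound 1 with Methyl

The source may report more compounds than this note shows. Statements on the series, on what has been measured and on what is new or still open speak of the compounds shown alone.

Compound 1 `O=C(Nc1cccc(-n2cc(-c3ccncc3)c(-c3cc(O)cc(Cl)c3)n2)c1)Nc1ccc(Cl)c(C(F)(F)F)c1` was tested in a functional assay on LOX IMVI cells (Homo sapiens) for inhibition, read by sulforhodamine B assay, with a stated time of 48 h, tested at 0.1 uM (on this read-out higher numbers stand for a weaker effect at the one concentration tested and lower numbers for a stronger effect), where compound 1 gives 95%. Compound 2 `O=C(Nc1cccc(-n2cc(-c3ccncc3)c(-c3cc(O)cc(Cl)c3)n2)c1)Nc1ccc(Cl)c(Cl)c1` differs from it in one place, and in this assay compound 2 gives 105%; the step is a number 10 percentage points higher from compound 1 to compound 2 (within the scatter). On these two numbers compound 1 stands lowest, with compound 2 its nearest neighbour, the two lying within the scatter of each other. Compound 3 `COc1cc(Cl)cc(-c2nn(-c3cccc(NC(=O)Nc4ccc(Cl)c(C(F)(F)F)c4)c3)cc2-c2ccncc2)c1` has not yet been measured. It differs from compound 1 in one place: methyl in place of hydrogen on an oxygen on an aromatic ring. Going by the values given here, no measured step touches this oxygen; the only measured step concerns a different group and itself stayed within the scatter. With nothing pointing either way, the expectation for compound 3 in this assay is a step of a number 1 percentage points higher from compound 1 to compound 3 (within the scatter), none beyond the scatter. Compound 3 is therefore estimated at 96%, with a range from 82% to 110%.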

Compound 3, a percentage reported as activity, at one concentration (the size of the read-out at that concentration, not a potency): 97%
Beside the measured number, compound 3's estimate is 1 percentage points below it, and the stated range covers the measured number.
By their numbers in this assay, from the lowest: compounds 1, 3 and 2 (each within the scatter of the next).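

In this assay, going by these compounds alone, capping the hydroxy group with methyl gives a number 2 percentage points higher from compound 1 to compound 3 (within the scatter) and is the first measured step at this oxygen on the aromatic ring. At this single concentration, the read-out therefore does not separate 3-chloro-5-hydroxyphenyl from 3-chloro-5-methoxyphenyl, and the hydrogen on that oxygen can be exchanged for methyl without the number leaving the usual scatter. Nothing measured here offers a reason for this result.

What the compounds shown leave open is whether a larger group on this oxygen, such as a longer chain, or an amine or a carboxylic acid in place of the hydroxy group, would move the number beyond the scatter. A single concentration also cannot show whether compound 1 and compound 3 would separate at other concentrations.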